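This account rests on a few compounds, and the source may have more. Where it says the series, first, only, none or still open, it means among the compounds named here.

The measured compounds:
Compound 1 `COc1ccc(NCc2cncn2Cc2ccc(-c3ccccc3)cc2N)cc1-c1ccccc1` in a toxicity assay on NIH3T3 cells (Mus musculus) for cytotoxicity, read by resazurin assay (a higher number here means that more compound is needed for the effect, a lower number that less compound is needed), gives > 1000 nM, a limit of the assay rather than a number.
Compound 2 `COC(=O)c1ccc(NCc2cncn2Cc2cccc(OC)c2)cc1-c1ccccc1` has in this assay the entry "not determined" (no result reported), so no value is available for it.
Compound 3 `c1ccc(-c2ccc(Cn3cncc3CNc3ccc(-c4ccccc4)c(-c4ccccc4)c3)cc2)cc1` gives in this assay the value > 10000 nM, which is again a limit and not a number.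

Compound 3 therefore stands at the limit of > 10000 nM in this assay, at which 1 of the 3 values shown sits, the higher of the two limits seen here, while compound 1 sits at the limit of > 1000 nM in this assay, at which 1 of the 3 values shown sits. Among the compounds with values here, none of the three compounds has a single number, and no step between measured compounds can be formed, so nothing is known about how large a change in this assay any alteration of the shared core produces.

Compound 4 `CC(=O)c1ccc(NCc2cncn2Cc2ccc(-c3ccccc3)cc2)cc1-c1ccccc1` has not been measured. It differs from compound 3 in one place: acetyl in place of phenyl on an aromatic carbon. Within the data shown here, with no measured step to rest on, the expectation is that this change leaves the reading where compound 3 has it, that is, no step beyond the scatter: the expected step is a number no higher from compound 3 to compound 4 (the limit leaves the size open). Compound 4 is accordingly estimated to give about 10000 nM in this assay, within a range from 2000 nM to 50000 nM, most likely again as a limit.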

Compound 4, half-maximal effective concentration: > 10000 nM
Compound 4 was reported as a limit; the forecaster's own chance of this, stated with the estimate: 70%; the middle value sits exactly at the limit.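

Within the data shown here, compound 3 and compound 4 are both reported in this assay only as limits, not as numbers, so no step between them can be read. The compounds shown leave open whether acetyl in place of phenyl on an aromatic carbon changes the reading at all, and by how much.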